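Notes on the ring exchange from compound 1 to compound 4

The source may hold more compounds than are shown below. What is called first, only, known or untested is meant among the compounds shown, and "the series" means these compounds.

In a functional assay on the whole organism with Rattus norvegicus as the target (on this read-out higher numbers stand for an effect only at larger amounts of compound and lower numbers for an effect already at smaller amounts), compound 1 (`CCOCCOC(=O)C(=O)Nc1nc(-c2cc(Cl)no2)cs1`) gives > 30 mg/kg, which is a limit and not a number. Compound 3 (`CCOCCOC(=O)C(=O)Nc1nc(-c2c(-c3c(F)cccc3Cl)noc2C)cs1`) gives > 30 mg/kg, which is also a limit. Compound 1 therefore stands at the limit of > 30 mg/kg in this assay, at which 2 of the 3 values shown sit. For the measured compounds named here, compound 2 (`CCOCCOC(=O)C(=O)Nc1nc(-c2cc(C(=O)OCC)no2)cs1`) gives 1.9 mg/kg, the only true number so far.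

Compound 4 (`CCOCCOC(=O)C(=O)Nc1nc(-c2cc(C)on2)cs1`) has not yet been measured. It carries 5-methyl-1,2-oxazol-3-yl in place of 3-chloro-1,2-oxazol-5-yl on an aromatic carbon. Going by the values given here, one measured step bears on this change. With ethoxycarbonyl in place of chloro, compound 2 shows a large step beyond the scatter, an at least 15-fold lower number from compound 1 to compound 2 (1.19 log units; beyond the scatter). That step leaves the attachment of the ring unchanged and brings in a much larger group than methyl, so it is only a loose guide, and just part of its size is expected here. Compound 3 remains a limit, so a true number for compound 4 is not assured.

A moderate move towards lower numbers in this assay is expected, estimated as an at least 2.0-fold lower number from compound 1 to compound 4 (0.30 log units; that floor lies within the scatter). The estimate for compound 4 is 15 mg/kg, with an expected range from 3 mg/kg to 60 mg/kg.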

Compound 4, dose for half-maximal effect: 2 mg/kg
Compound 4: the middle estimate sits 7.5-fold (0.88 log units) above what was measured; measured number below the stated range.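

The exchange of 3-chloro-1,2-oxazol-5-yl for 5-methyl-1,2-oxazol-3-yl gives an at least 15-fold lower number from compound 1 to compound 4 (1.17 log units; beyond the scatter) in this assay, so a large step at this position does not need a group as large as ethoxycarbonyl: the entering and leaving groups here have the same heavy-atom count. Compound 2 gives 1.9 mg/kg and compound 4 gives 2 mg/kg, and these two values allow no order between them, so two quite different groups on this aromatic carbon arrive at the same level. Compound 1 gives a limit and not a number, which leaves the full size of the step unknown: the limit of > 30 mg/kg in this assay, at which 2 of the 4 values shown sit.

Open, from the compounds shown here alone, is which part of the exchange carries the step, as the ring attachment and the substituent change together from compound 1 to compound 4, and only 3-methyl-1,2-oxazol-5-yl or 5-chloro-1,2-oxazol-3-yl would separate the two. Also open, going by these compounds, is how the read-out would respond to an amine, a carboxylic acid or a longer alkyl chain in place of the methyl group of compound 4.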